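From one selenium atom to methylsulfanyl: compound 2 to 4

The source may hold more compounds than are shown below. What is called first, only, known or untested is meant among the compounds shown, and "the series" means these compounds.

Three measured members of the series sit close together. In a functional assay on MCF7 cells (Homo sapiens) for cytotoxicity, read by MTT assay, with a stated time of 72 h (a higher number here means a weaker inhibitor of growth, a lower number a stronger inhibitor of growth), compound 1 `CCCCC[Se]c1nc(N)c2ccccc2n1` gives 28600 nM, compound 3 `C[Se]c1nc(N)c2ccccc2n1` gives 46500 nM and compound 2 `COc1ccc(CNc2nc([SeH])nc3ccccc23)cc1` gives 42700 nM. Within the data shown here, the only one-place step among them, a 1.6-fold higher number from compound 1 to compound 3 (0.21 log units; within the scatter), lies within the scatter. Compound 2 stands second highest of the three numbers, nearest to compound 3 and furthest from compound 1, with both gaps within the scatter, so no order can be read among the three.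

Compound 4 `COc1ccc(CNc2nc(SC)nc3ccccc23)cc1` is not yet measured. It differs from compound 2 in one place: a group of 2 heavy atoms (1 carbon, 1 sulfur; no ring) in place of one selenium atom, on an aromatic carbon. Among the measured compounds shown here, no measured step concerns this exchange; the step from compound 1 to compound 3 changes what is bound to a selenium atom on a saturated chain carbon, not the ring carbon itself, and it stayed within the scatter. What the data show is a narrow band of numbers whatever group is bound to the selenium atom in compounds 1 and 3. Compound 4 is therefore expected to remain in that band. For compound 4 the expected step is a 1.1-fold lower number from compound 2 to compound 4 (0.03 log units; within the scatter), none beyond the scatter. The estimate for compound 4 is 40000 nM, ranging from 15000 nM to 100000 nM.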

Compound 4, concentration for 50% growth inhibition: 30900 nM
For compound 4 the middle estimate is 1.3-fold (0.11 log units) above the measured one; measured number inside the range.
By their numbers in this assay, from the lowest: compounds 1, 4, 2 and 3 (each within the scatter of the next).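

In this assay, replacing the selenium atom with methylsulfanyl on the aromatic carbon between two ring nitrogen atoms gives a 1.4-fold lower number from compound 2 to compound 4 (0.14 log units; within the scatter). Among these compounds, this is the first direct reading at this position, as the earlier step concerned only what is bound to a selenium atom on a saturated chain carbon; within this pair, a number inside the scatter of compound 2 does not depend on selenium being present, as compound 4 carries none. No accompanying measurement bears on this result, so the step remains a bare observation.

The exchange alters the heteroatom and adds a carbon in a single step, so the shown compounds cannot separate the two changes, and a methylselanyl group on the same core as compound 4 would be needed to isolate the exchange of selenium for sulfur. Also open, from the compounds shown here alone, is whether this position stays as undemanding with a group of another kind, such as an amine, a hydroxyl or a longer chain like pentylsulfanyl, in place of methylsulfanyl.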